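Methyl in place of hydroxy on compound 2

The source may hold more compounds than are shown below. What is called first, only, known or untested is meant among the compounds shown, and "the series" means these compounds.

Measured so far:
Compound 1 `Cc1cccc(CNc2ncnc3c2ncn3[C@@H]2O[C@H](CO)[C@@H](O)[C@H]2O)c1`: > 166000 nM, a limit of the assay
Compound 2 `OC[C@H]1O[C@@H](n2cnc3c(NCc4cccc(O)c4O)ncnc32)[C@H](O)[C@@H]1O`: 25800 nM

Within the data shown here, in a functional assay on K562 cells (Homo sapiens) for antiproliferative activity, with a stated time of 72 h (on this read-out higher numbers stand for weaker inhibition and lower numbers for stronger inhibition), compound 2 gives 25800 nM, the only actual number so far. The value of compound 1 is a limit of the assay. Compound 3 `Cc1cccc(CNc2ncnc3c2ncn3[C@@H]2O[C@H](CO)[C@@H](O)[C@H]2O)c1O` differs from compound 2 by one change: methyl in place of hydroxy on an aromatic carbon. The methyl takes the place of a hydroxy on an aromatic carbon, ortho to a hydroxy group and meta to a large group, so 2,3-dihydroxyphenyl becomes 2-hydroxy-3-methylphenyl.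

Among the measured compounds shown here, one measured step bears on this: an at least 6.4-fold lower number from compound 1 to compound 2 (0.80 log units; beyond the scatter). There, 2,3-dihydroxyphenyl replaced 3-methylphenyl. The size of that step rests on (the limit of > 166000 nM in this assay, at which 1 of the 2 values shown sits). Compound 3 carries a methyl as compound 1 does and keeps one hydroxy of compound 2, so it is expected to recover only part of an at least 6.4-fold lower number from compound 1 to compound 2 (0.80 log units; beyond the scatter). In this assay a move to a higher number, meaning weaker inhibition, is therefore expected, with an estimated 2.1-fold higher number from compound 2 to compound 3 (0.33 log units; beyond the scatter). The estimate for compound 3 is 55000 nM, with an expected range of 20000 nM to 150000 nM.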

Compound 3, half-maximal inhibitory concentration: 18000 nM
Beside the measured number, compound 3's estimate is 3.1-fold (0.49 log units) above it; measured number below the stated range.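

In this assay, the place that held a hydroxy in compound 2 also accepts a methyl, with no difference beyond the scatter: a 1.4-fold lower number from compound 2 to compound 3 (0.16 log units; within the scatter). So the hydroxy on this aromatic carbon, ortho to a hydroxy group, is not required for the level of inhibition seen in this pair, and a hydrogen-bond donor count lower by one at this place goes with no readable change. The hydroxy retained in the 2-hydroxy-3-methylphenyl group then carries the difference from the 3-methylphenyl group, since hydroxy in place of hydrogen on an aromatic carbon gives an at least 9.2-fold lower number from compound 1 to compound 3 (0.96 log units; beyond the scatter), though that size is only a bound on a limit value of compound 1: the limit of > 166000 nM in this assay, at which 1 of the 3 values shown sits.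

The compounds shown leave open whether the retained hydroxy must remain a hydroxy, as a methoxy or an amine in its place would tell. They also leave open whether the methyl contributes at all, which a 2-hydroxyphenyl group with hydrogen at that place would show, and how far a longer chain such as ethyl would be accepted there.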